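Selenocyanate carbamates: fluoro to hydrogen on the aryl carbamate

This account rests on a few compounds, and the source may have more. Where it says the series, first, only, none or still open, it means among the compounds named here.

Measured compounds:
compound 1: `CCCCOC(=O)Nc1ccc([Se]C#N)cc1`, 8100 nM
compound 2: `N#C[Se]c1ccc(NC(=O)Oc2ccc(F)cc2)cc1`, 8800 nM

In a functional assay on HT-29 cells (Homo sapiens) for cytotoxicity, read by MTT assay, with a stated time of 72 h (a higher number here means a weaker inhibitor of growth, a lower number a stronger inhibitor of growth), compound 1 gives 8100 nM and compound 2 gives 8800 nM. Compound 2 holds the higher of the two numbers, but the two values lie within the scatter of each other, so no order can be read from them. Compound 3 `N#C[Se]c1ccc(NC(=O)Oc2ccccc2)cc1` has not yet been measured in this assay. It differs from compound 2 by hydrogen in place of fluoro on an aromatic carbon. Among the measured compounds shown here, no step between measured compounds is available, so no size for this kind of change can be read from the data. Only a small step is expected, likely none beyond the scatter, in either direction. Compound 3 is therefore expected to give about 8500 nM in this assay, with a range from 4000 nM to 18000 nM. The expected step of a 1.0-fold lower number from compound 2 to compound 3 (0.02 log units; within the scatter) is estimated to stay within the scatter.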

Compound 3, concentration for 50% growth inhibition: 11700 nM
The estimate for compound 3 lay 1.4-fold (0.14 log units) below the measured number; the range from low to high includes it.
By their numbers in this assay, from the lowest: compounds 1, 2 and 3 (each within the scatter of the next).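

In this assay hydrogen in place of fluoro on an aromatic carbon gives the first step of this kind in the series (a 1.3-fold higher number from compound 2 to compound 3 (0.12 log units; within the scatter)), and it stays within the scatter. Phenyl in place of butyl gives a step of similar standing (a 1.4-fold higher number from compound 1 to compound 3 (0.16 log units; within the scatter)), also within the scatter, so neither of these changes separates the compounds in this assay. Nothing at hand bears on the reason for these results.

Going by these compounds, whether an amine or a methoxy group in place of fluoro, or a longer chain in place of butyl, would move the number beyond the scatter remains open. The part played by the selenocyanate also remains open, since all the compounds shown carry it and none has a thiocyanate in its place.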